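Swapping the sulfonamide side chain for methoxyphenyl

The source may hold more compounds than are shown below. What is called first, only, known or untested is meant among the compounds shown, and "the series" means these compounds.

Compound 1, `Cc1ccc(-c2cn(C/C=C3\OC(=O)C(OCc4ccccc4)=C3OCc3ccccc3)nn2)cc1`: > 100000 nM
Compound 2, `O=C1O[C@H]([C@@H](O)Cn2cc(CNS(=O)(=O)c3ccc(F)cc3)nn2)C(OCc2ccccc2)=C1OCc1ccccc1`: 30 nM

Both measured compounds were read in an ADME assay on HFF cells (Homo sapiens) for cytotoxicity, read by MTT assay, with a stated time of 72 h; a higher number here means a weaker inhibitor, a lower number a stronger inhibitor. For compound 1 the result is a limit of that assay, (the limit of > 100000 nM in this assay, at which 1 of the 2 values shown sits), so no number is known for it. Among the compounds with values here, compound 2 gives 30 nM, the only number among the values shown. Within the data shown here, compound 1 and compound 2 differ in more than one place, so their pair yields no single step; their two values show only that one sits at the limit while the other lies well inside the measured range.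

Compound 3, `COc1ccc(-c2cn(C[C@H](O)[C@H]3OC(=O)C(OCc4ccccc4)=C3OCc3ccccc3)nn2)cc1`, keeps the core of compound 2 and changes one position: 4-methoxyphenyl in place of (((4-fluorophenyl)sulfonyl)amino)methyl on an aromatic carbon. Among the measured compounds shown here, no step between measured compounds guides this change. Compound 1, which also carries a six-membered aromatic ring of carbon only on the five-membered aromatic ring with 3 nitrogen, sits at the limit (the limit of > 100000 nM in this assay, at which 1 of the 2 values shown sits), and this points toward a loss of potency. The step is estimated at a 100-fold higher number from compound 2 to compound 3 (2.00 log units; beyond the scatter), a clear loss beyond the scatter. Compound 3 is thus expected at 3000 nM, within 300 nM to 50000 nM.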

Compound 3, half-maximal inhibitory concentration: < 10 nM
Compound 3 was reported as a limit; the forecaster's own chance of this, stated with the estimate: 25%; middle value at least 300-fold (2.47 log units) from the limit.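

In this assay compound 3 gives < 10 nM, which is a limit and not a number: the limit of < 10 nM in this assay, at which 1 of the 3 values shown sits. Putting 4-methoxyphenyl in place of (((4-fluorophenyl)sulfonyl)amino)methyl gives an at least 3.0-fold lower number from compound 2 to compound 3 (0.47 log units; beyond the scatter), so the sulfonamide side chain is not needed for a low number at this aromatic carbon. Compound 1 also carries a six-membered aromatic ring of carbon only on the ring with 3 nitrogen, so compound 3 shows that such a ring here does not by itself go with the limit seen for compound 1, which differs from compound 3 in more than this place.

On these data alone, how far compound 3 lies beyond its limit stays open, and with it the full size of the step. Also open, as far as these compounds go, is whether an amine or a carboxylic acid on this aromatic carbon would keep the number this low.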